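Swapping the Styryl Arm for a Dimethoxyphenyl Ring

The compounds below may be only part of what the source reports. "The series", "measured", "known", "first", "only" and "open" are said of these compounds alone.

Going by the values given here, compound 2 `Cc1cc(O)c(C2=NN(c3ccc(S(N)(=O)=O)cc3)C(/C=C/c3ccccc3)C2)cc1Cl` is one of two compounds tested in a functional assay on SR cells (Homo sapiens) for antiproliferative activity, with a stated time of 48 h; on this read-out higher numbers stand for lower toxicity in this test and lower numbers for higher toxicity in this test; in this assay compound 2 gives 89700 nM, the only plain number in the set. Compound 1 `Cc1cc(O)c(C2=NN(c3ccc(S(N)(=O)=O)cc3)C(c3ccccc3O)C2)cc1Cl` differs in carrying a 2-hydroxyphenyl group on the same saturated ring carbon. In this assay compound 1 reaches only the limit of > 100000 nM. The step of an at least 1.1-fold lower number from compound 1 to compound 2 (0.04 log units; that floor lies within the scatter) rests on the limit of > 100000 nM in this assay, at which 1 of the 2 values shown sits, and lies within the scatter. Compound 3 `COc1ccc(C2CC(c3cc(Cl)c(C)cc3O)=NN2c2ccc(S(N)(=O)=O)cc2)cc1OC` carries 3,4-dimethoxyphenyl in place of 2-phenylethenyl on a saturated ring carbon. Among the compounds with values here, the one measured step exchanged a different group at the same position without moving beyond the scatter, so the same outcome is expected here. The step from compound 2 to compound 3 is estimated at a 1.1-fold higher number from compound 2 to compound 3 (0.05 log units; within the scatter). For compound 3 the value expected in this assay is 100000 nM, within a range from 40000 nM to 250000 nM, with a real chance that only a limit is reported.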

Compound 3, concentration lethal to 50% of the cells: > 100000 nM
Compound 3 ended at the assay's limit; the forecaster's own chance of this, stated with the estimate: 50%; the middle value lies on the limit itself.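

Putting 3,4-dimethoxyphenyl in place of 2-phenylethenyl on the saturated ring carbon gives, in this assay, an at least 1.1-fold higher number from compound 2 to compound 3 (0.04 log units; that floor lies within the scatter). So this position has now carried a ring with two methoxy groups and its 2 hydrogen-bond acceptors, as well as a 2-hydroxyphenyl and a 2-phenylethenyl group, and no readable step among the three compounds goes beyond the scatter. The result for compound 3 is a limit, not a number, and the step between compound 1 and compound 3 cannot be read, because both values are limits: the limit of > 100000 nM in this assay, at which 2 of the 3 values shown sit.

Going by these compounds, whether an amine, a carboxylic acid or a longer alkyl chain on this carbon would bring the number clearly down remains open. On these data alone, how far compound 1 and compound 3 truly lie past the limit also remains open.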